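The source may report more compounds than this note shows. Statements on the series, on what has been measured and on what is new or still open speak of the compounds shown alone.

Compound 2 `COc1ccc([C@H]2NC(=O)O[C@@H]2CO)cc1` gives 31200 nM in a functional assay on A549 cells (Homo sapiens) for cytotoxicity (on this read-out lower numbers stand for stronger inhibition and higher numbers for weaker inhibition), and compound 1 `COc1ccc([C@H]2NC(=O)O[C@H]2CO)cc1` gives 25500 nM in this assay, the two numbers lying within the usual scatter of each other. The step of a 1.2-fold higher number from compound 1 to compound 2 (0.09 log units; within the scatter) rests on (the fact that compounds 1 and 2 differ only in the configuration as drawn). Compound 3 `C=C[C@H]1OC(=O)N[C@@H]1c1ccc(OC)cc1` differs from compound 2 by vinyl in place of hydroxymethyl on a saturated ring carbon. Among the compounds with values here, the only measured step changes configuration alone and leaves every group in place, so it does not speak to swapping one group for another, and no step beyond the scatter is expected in this assay. Compound 3 is therefore estimated at 30000 nM, with a range from 8000 nM to 100000 nM, a step of a 1.0-fold lower number from compound 2 to compound 3 (0.02 log units; within the scatter).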

Compound 3, half-maximal inhibitory concentration: 21300 nM
Compound 3: middle estimate off by 1.4-fold (0.15 log units), on the high side; measured number inside the range.
By their numbers in this assay, from the lowest: compounds 3, 1 and 2 (each within the scatter of the next).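

In this assay the swap of hydroxymethyl for vinyl on this saturated ring carbon gives a 1.5-fold lower number from compound 2 to compound 3 (0.17 log units; within the scatter) even though the entering group has no hydrogen-bond donor or acceptor. So, for this one pair, a change of group at this position, and not only a change of configuration, stays within the scatter. Nothing in hand accounts for this result. Open, from the compounds shown here alone, is whether an amine, a carboxylic acid or a longer chain on this carbon would give a step beyond the scatter.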